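Swapping the Side Chain on the Acid Arm of Compound 2

This account rests on a few compounds, and the source may have more. Where it says the series, first, only, none or still open, it means among the compounds named here.

Three compounds sharing one core have been taken through a functional assay on the whole organism (Tail, strain ICR) with Mus musculus as the target, in the tail flick test, with a stated time of 60 min, at a dose of 25 umol/kg by the oral route; a lower number here means a weaker effect, a higher number a stronger effect of the compound at the dose given. Compound 1 `O=C(CN(c1nc(Cl)nc2[nH]cnc12)C1CC1)N[C@@H](CC(=O)OCc1ccccc1)C(=O)OCc1ccccc1` gives 22.4% in this assay. Compound 2 `NC(=O)C[C@H](NC(=O)CN(c1nc(Cl)nc2[nH]cnc12)C1CC1)C(=O)O` gives 43.1%. Compound 3 `O=C(CN(c1ncnc2c1ncn2C1CCCCO1)C1CC1)N[C@@H](CC(=O)OCc1ccccc1)C(=O)OCc1ccccc1` gives 38.2%. Compound 2 thus shows the highest of the three numbers; its gap to compound 3 lies within the usual scatter of repeated measurements, so the two cannot be ordered, while its gap to compound 1 lies beyond it.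

Compound 4 `CSCC[C@H](NC(=O)CN(c1nc(Cl)nc2[nH]cnc12)C1CC1)C(=O)O` has not yet been measured in this assay. It differs from compound 2 in one place: (methylsulfanyl)methyl in place of carbamoyl on a saturated chain carbon, two bonds along the chain from an amide-type nitrogen and a carbonyl carbon. Among the measured compounds shown here, no pair of measured compounds carries this change, so the size of the step is open. Since compound 2 and compound 3 sit close together, the writer expects compound 4 to stay in the same region, with a step of a number 5.1 percentage points lower from compound 2 to compound 4 (within the scatter) that may fall within the scatter. Compound 4 is estimated at 38%, with a range from 22% to 55%.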

Compound 4, a percentage reported as activity, at one dose (the size of the read-out at that dose, not a potency): 22.8%
For compound 4 the middle estimate is 15.2 percentage points above the measured one; the measured number falls inside the stated range.
By their numbers in this assay, from the lowest: compounds 1 and 4 (each within the scatter of the next); then compounds 3 and 2 (each within the scatter of the next).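

In this assay, among the compounds shown here, putting (methylsulfanyl)methyl in place of carbamoyl at this saturated chain carbon gives a number 20.3 percentage points lower from compound 2 to compound 4 (beyond the scatter), the first step that can be read for a change in one place. The earlier compounds shown here could not isolate this position, and this step shows that the read-out at the dose given depends on the group held there, even though the heavy-atom count of the group stays the same. No evidence is at hand that accounts for this step.

On these data alone, it remains open whether another group at this place, such as an amine, a carboxylic acid or a longer chain, would give a number closer to that of compound 2 or to that of compound 4. As far as these compounds go, whether the same change would give a similar step in the other compounds also remains open.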